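Swapping the thiazole for an aminophenyl on the amide

The compounds below may be only part of what the source reports. "The series", "measured", "known", "first", "only" and "open" are said of these compounds alone.

Compound 1, `N#Cc1ccc(C(=O)Nc2cccc(NC(=O)COc3ccc4c(=O)ccoc4c3)c2)cc1`, gives 123 nM.
Compound 2, `Cc1nc(C(=O)Nc2cccc(NC(=O)COc3ccc4c(=O)ccoc4c3)c2)cs1`, gives 473 nM.

Both numbers come from an assay on isolated protein for inhibition of Rho-associated protein kinase 1 (Homo sapiens), read by scintillation counting, radiometric assay and 33P incorporation, with a stated time of 40 min, in the presence of a further agent that is not named here; on this read-out higher numbers stand for weaker inhibition and lower numbers for stronger inhibition. Among the compounds with values here, compound 2 stands at the highest of the two numbers, meaning the weaker inhibition of the pair; its only neighbour is compound 1, and the sole measured step is a 3.8-fold higher number from compound 1 to compound 2 (0.58 log units; beyond the scatter), a change that moved the number upward once a six-membered carbon ring on the carbonyl carbon was replaced by a five-membered ring with two hetero atoms.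

Compound 3, `Nc1cccc(C(=O)Nc2cccc(NC(=O)COc3ccc4c(=O)ccoc4c3)c2)c1`, is not yet measured. It differs from compound 2 by 3-aminophenyl in place of 2-methyl-1,3-thiazol-4-yl on a carbonyl carbon. Within the data shown here, this reverses the kind of change seen in the one measured step, returning to a six-membered carbon ring, though with a different substituent than compound 1 carries. Because that step, a 3.8-fold higher number from compound 1 to compound 2 (0.58 log units; beyond the scatter), was of modest size and went upward, a step of similar size downward is expected here, with added uncertainty from the new substituent.

For compound 3 the estimate in this assay is 180 nM, with a range from 60 nM to 600 nM. This estimate corresponds to a 2.6-fold lower number from compound 2 to compound 3 (0.42 log units; beyond the scatter).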

Compound 3, half-maximal inhibitory concentration: 670 nM
Compound 3: middle estimate off by 3.7-fold (0.57 log units), on the low side; the whole stated range lies below it.
By their numbers in this assay, from the lowest: compound 1; then compounds 2 and 3 (each within the scatter of the next).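

Having a six-membered ring of carbon only on the carbonyl carbon is not enough on its own to give a low number in this assay: the step is a 1.4-fold higher number from compound 2 to compound 3 (0.15 log units; within the scatter) and so does not separate 3-aminophenyl from 2-methyl-1,3-thiazol-4-yl. The comparison that does separate two groups is a 5.4-fold higher number from compound 1 to compound 3 (0.74 log units; beyond the scatter) and shows that, with the ring type kept, what the ring carries still matters at this position. Compound 1 remains alone at the low end of the three, and no measurement at hand explains that.

Going from 4-cyanophenyl to 3-aminophenyl changes both the group on the ring and its place on that ring, and the compounds shown cannot tell these two changes apart. They also leave open how an unsubstituted phenyl, or a phenyl carrying a carboxylic acid, would read on this carbonyl carbon.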